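Swapping Bromo for Hydroxy on a Flavanone Aryl Ring

A few compounds are considered here, and "the series" means these few. Any claim that something is new, unique, unknown or untested is made for them only; others in the source may bear on it.

Of the compounds shown here, two have so far been tested in a functional assay on aorta (Rattus norvegicus, strain Sprague-Dawley) for inhibition, with a stated time of 20 min; on this read-out higher numbers stand for larger maximal responses and lower numbers for smaller maximal responses. Compound 1 `C=CCc1c(O)cc(O)c(C(=O)/C=C/c2ccc(O)cc2)c1O` is an open-chain compound bearing an allyl chain and several hydroxy groups; in this assay compound 1 gives 108%. Compound 2 `C=CCc1c(O)cc(O)c2c1OC(c1cccc(Br)c1)CC2=O` is a ring-closed relative whose pendant aryl ring carries a bromo group; in this assay compound 2 gives 78.8%. Of the two numbers, compound 2 holds the lower one, and its gap to compound 1 lies beyond the usual scatter of the method. Among the measured compounds shown here, no single-change step between these two has been worked out, so only the two values themselves can be set side by side.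

Compound 3 `C=CCc1c(O)cc(O)c2c1OC(c1cccc(O)c1)CC2=O` has not yet been measured. It differs from compound 2 in one place: hydroxy in place of bromo on an aromatic carbon. For the measured compounds named here, no measured pair shows what this exchange does in this assay, so the expectation rests only on where compound 2 sits. The expected change is a number 7.2 percentage points higher from compound 2 to compound 3 (within the scatter), a modest step that stays within the scatter. Compound 3 is accordingly expected to reach about 86%, with a plausible range from 68% to 104%.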

Compound 3, largest response reached (Emax), in percent of the reference or control that the assay uses: 97.8%
Beside the measured number, compound 3's estimate is 11.8 percentage points below it, within the range that was stated.
By their numbers in this assay, from the lowest: compound 2; then compound 3; then compound 1.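

On the pendant aryl ring of the ring-closed compounds, the aromatic carbon that holds bromo in compound 2 turns out to matter for this read-out: in this assay, placing hydroxy there instead of bromo gives a number 19 percentage points higher from compound 2 to compound 3 (beyond the scatter) and so a larger maximal response. Among the compounds shown here, this is the first single-change step in the set, so the exchange of 3-bromophenyl to 3-hydroxyphenyl now has a measured direction and size, whereas compound 1 and compound 2 differ in more than one place and could only be set side by side. Hydroxy brings a hydrogen-bond donor and a hydrogen-bond acceptor that bromo does not, but no measurement here connects those counts to the step, and nothing available explains why the response changes.

Going by these compounds, this is a single pair, so it remains open where other groups at this place, such as an amine, a methoxy group or a carboxylic acid, would fall relative to compound 2 and compound 3. On these data alone, it also remains open whether the same exchange would give a similar step on an open-chain compound such as compound 1.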